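Aryl swap on the hydrazone carbon of the shared core

This account rests on a few compounds, and the source may have more. Where it says the series, first, only, none or still open, it means among the compounds named here.

Compound 1 `Cn1c(=O)c(=O)n(C2CCCC2)c2nc(N/N=C/c3cccc(O)c3)ncc21` and compound 2 `Cn1c(=O)c(=O)n(C2CCCC2)c2nc(N/N=C/c3cc([N+](=O)[O-])ccc3Cl)ncc21` share one core and differ only in the aryl group on the carbon with a double bond to nitrogen. In a functional assay on PC-3 cells (Homo sapiens) for antiproliferative activity, read by MTT assay (a lower number here means a stronger inhibitor, a higher number a weaker inhibitor), compound 1 gives 36300 nM, and compound 2 gives 9260 nM. Among the measured compounds shown here, the step of a 3.9-fold lower number from compound 1 to compound 2 (0.59 log units; beyond the scatter) is the only measured step in the set, and compound 2 stands with the lowest of the two numbers. Compound 3 `Cn1c(=O)c(=O)n(C2CCCC2)c2nc(N/N=C/c3ccc(F)cc3F)ncc21` is not yet measured; it carries the change (2,4-difluorophenyl in place of 2-chloro-5-nitrophenyl on a carbon with a double bond to nitrogen). The step from compound 1 to compound 2 is also an aryl-for-aryl exchange at the same place, but neither measured compound carries the entering group, so that step only shows that such an exchange can move this assay by a modest amount, and gives no direction for this one. For compound 3 the expected step is a 1.6-fold higher number from compound 2 to compound 3 (0.21 log units; within the scatter), with the direction uncertain. In this assay compound 3 is therefore estimated at 15000 nM, within a range from 4000 nM to 60000 nM.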

Compound 3, half-maximal inhibitory concentration: 13200 nM
The estimate for compound 3 lay 1.1-fold (0.06 log units) above the measured number; low and high end bracket the measured number.
By their numbers in this assay, from the lowest: compounds 2 and 3 (each within the scatter of the next); then compound 1.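

In this assay, the exchange at this carbon with a double bond to nitrogen gives a 1.4-fold higher number from compound 2 to compound 3 (0.15 log units; within the scatter), so the 2-chloro-5-nitrophenyl and 2,4-difluorophenyl groups cannot be told apart here, and neither the chlorine nor the nitro group is needed to reach this level. Against the 3-hydroxyphenyl group the result is a 2.8-fold lower number from compound 1 to compound 3 (0.44 log units; beyond the scatter), which means two differently substituted aryl groups now stand beyond the scatter from compound 1, and the gain seen with compound 2 is not unique to its group. No measured evidence accounts for either step.

Going by these compounds, it remains open whether the higher number of compound 1 follows from the hydroxyl group itself or from where it sits on the ring. On these data alone, how an unsubstituted phenyl ring, or a phenyl ring carrying an amine or a carboxylic acid, would read at this carbon also remains open.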